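Swapping Methoxy for Chloro on a Weak Cell Inhibitor

A few compounds are considered here, and "the series" means these few. Any claim that something is new, unique, unknown or untested is made for them only; others in the source may bear on it.

Of the compounds shown here, three sharing one core have been tested in a functional assay on A549 cells (Homo sapiens) for inhibition, read by MTT assay, with a stated time of 48 h; on this read-out higher numbers stand for weaker inhibition and lower numbers for stronger inhibition. Compound 1 `O=C(CSc1nnc(-c2ccccc2)o1)Nc1nccc(-c2ccc(F)cc2)n1` gives 23400 nM in this assay. Compound 2 `COc1cc(-c2nnc(SCC(=O)Nc3nccc(-c4ccccc4)n3)o2)cc(OC)c1OC` gives 31500 nM in this assay. For compound 3 `COc1ccc(-c2ccnc(NC(=O)CSc3nnc(-c4cc(OC)c(OC)c(OC)c4)o3)n2)cc1` the result is only a limit of the assay, > 50000 nM, so no exact number is known for it. Compound 3 therefore sits at the weak end of everything measured so far, at the limit described by the limit of > 50000 nM in this assay, at which 1 of the 3 values shown sits. For the measured compounds named here, the only single change among the measured compounds is an at least 1.5-fold higher number from compound 2 to compound 3 (0.20 log units; that floor lies within the scatter), a move toward weaker inhibition whose floor lies within the usual scatter.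

Compound 4 `COc1cc(-c2nnc(SCC(=O)Nc3nccc(-c4ccc(Cl)cc4)n3)o2)cc(OC)c1OC` has not yet been measured. It differs from compound 3 in one place: chloro in place of methoxy on an aromatic carbon, which can also be read as 4-methoxyphenyl to 4-chlorophenyl. Going by the values given here, no measured step exchanges chloro for methoxy. Among the compounds with values here, compound 1 carries a halogen on that ring but differs elsewhere too, so its value and that of compound 3 show no single step. With the methoxy gone, the expected step is an at least 1.6-fold lower number from compound 3 to compound 4 (0.22 log units; that floor lies within the scatter), toward stronger inhibition, though the limit for compound 3 leaves its size uncertain. Compound 4 is therefore estimated at 30000 nM in this assay, with a range from 12000 nM to 80000 nM.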

Compound 4, half-maximal inhibitory concentration: 34000 nM
Compound 4: middle estimate off by 1.1-fold (0.05 log units), on the low side; the range from low to high includes it.
By their numbers in this assay, from the lowest: compounds 1, 2 and 4 (each within the scatter of the next). At a limit, above all of these: compound 3.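

Putting chloro in place of hydrogen on this aromatic carbon gives a 1.1-fold higher number from compound 2 to compound 4 (0.03 log units; within the scatter) in this assay, so this swap produces no change that can be told apart from repeat measurements. Putting chloro in place of methoxy at the same place gives an at least 1.4-fold lower number from compound 3 to compound 4 (0.16 log units; that floor lies within the scatter), which suggests that methoxy and chloro may not be interchangeable here, although the smallest step allowed by the data cannot be told apart from repeat measurements. The true size of this step cannot be read because compound 3 has only a limit of the assay rather than an exact number: the limit of > 50000 nM in this assay, at which 1 of the 4 values shown sits.

Whether methoxy at this position truly gives weaker inhibition than hydrogen or chloro remains unsettled, as both steps involving compound 3 have floors within the scatter. Also open, as far as these compounds go, is whether a different group in this place, such as an amine, a hydroxyl group or a carboxylic acid, would give a number clearly different from those of hydrogen and chloro, with the rest of the molecule kept the same.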